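The source may hold more compounds than are shown below. What is called first, only, known or untested is meant among the compounds shown, and "the series" means these compounds.

Measured so far in a functional assay on NCI/ADR cells (Homo sapiens) for cytotoxicity, read by sulforhodamine B assay; a lower number here means a stronger inhibitor of growth, a higher number a weaker inhibitor of growth:
compound 1 `COc1ccc(/C=N\NC(=S)NC(C)(C)CCC[C@](C)(O)[C@@H]2CC=C(C)CC2)cc1` gives 6730 nM
compound 2 `CC1=CC[C@@H]([C@@](C)(O)CCCC(C)(C)NC(=S)N/N=C\c2cccc([N+](=O)[O-])c2)CC1` gives 6720 nM

For the measured compounds named here, only these two numbers exist, and together they show a 1.0-fold lower number from compound 1 to compound 2 (0.00 log units; within the scatter), so compound 1 cannot be ranked against its one neighbour. Compound 3 `CC1=CC[C@@H]([C@@](C)(O)CCCC(C)(C)NC(=S)N/N=C\c2cccc(Cl)c2)CC1` has not yet been measured. It keeps the shared core of compound 1 and alters a single group, (3-chlorophenyl in place of 4-methoxyphenyl on a carbon with a double bond to nitrogen). Put simply, 3-chlorophenyl stands in place of 4-methoxyphenyl on a carbon with a double bond to nitrogen.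

Going by the values given here, one measured step bears on this change. It removes the same 4-methoxyphenyl from the same place and puts 3-nitrophenyl there, and the result was a 1.0-fold lower number from compound 1 to compound 2 (0.00 log units; within the scatter). A single step is thin evidence, and no compound with 3-chlorophenyl has been measured yet, but it gives no reason to expect a real shift in either direction. The expected result is therefore no change beyond the scatter, an estimated 1.1-fold lower number from compound 1 to compound 3 (0.05 log units; within the scatter) in this assay. For compound 3 the estimated value is 6000 nM, with an expected range of 2800 nM to 12000 nM.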

Compound 3, concentration for 50% growth inhibition: 7350 nM
Compound 3: middle estimate off by 1.2-fold (0.09 log units), on the low side, within the range that was stated.
By their numbers in this assay, from the lowest: compounds 2, 1 and 3 (each within the scatter of the next).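

Compound 3 adds a second replacement for 4-methoxyphenyl on a carbon with a double bond to nitrogen, and in this assay the swap to 3-chlorophenyl gives a 1.1-fold higher number from compound 1 to compound 3 (0.04 log units; within the scatter). The chloro group in place of the nitro group on the aromatic carbon gives a 1.1-fold higher number from compound 2 to compound 3 (0.04 log units; within the scatter), so this comparison, which the earlier pair could not offer, also finds no difference beyond the scatter. Across these three compounds, 4-methoxyphenyl, 3-nitrophenyl and 3-chlorophenyl cannot be told apart at this place, none of the three goes against that reading, and nothing available explains why they read alike.

All three groups shown here are substituted phenyl rings, so it remains open whether a different kind of group at this place, such as an aminophenyl, a carboxylic acid on the ring or a small alkyl chain replacing the ring altogether, would move the number beyond the scatter. From the compounds shown here alone, it also remains open whether changes elsewhere on the shared core, for example to its hydroxyl group or to the thiocarbonyl, would matter more than any change at this place.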